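The source may report more compounds than this note shows. Statements on the series, on what has been measured and on what is new or still open speak of the compounds shown alone.

Measured so far in a functional assay, with a stated time of 30 min, in the absence of a further agent; on this read-out lower numbers stand for stronger inhibition and higher numbers for weaker inhibition
- compound 1 `O=C(COc1ccccc1)Nc1nnc(-c2cccc(O)c2O)s1` gives 16600 nM
- compound 2 `O=C(COc1ccccc1)Nc1nnc(-c2ccc(O)c(O)c2)s1` gives 36100 nM
- compound 3 `O=C(Nc1nnc(-c2ccc(O)c(O)c2)s1)c1ccc(Cl)cc1` gives 53000 nM

Compound 1 has the lowest number of the three, and the values of the other two both lie beyond the scatter from it. The next compound to consider is compound 4 `CC(=O)Nc1nnc(-c2cccc(O)c2O)s1`, which has no value yet. It differs from compound 1 by hydrogen in place of phenoxy on a saturated chain carbon bound to a carbonyl carbon, so phenoxymethyl becomes methyl (hydrogen in place of phenoxy on a saturated chain carbon bound to a carbonyl carbon).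

Two measured steps offer some guidance. One is a 2.2-fold higher number from compound 1 to compound 2 (0.34 log units; beyond the scatter), but it swaps 2,3-dihydroxyphenyl for 3,4-dihydroxyphenyl and leaves the phenoxymethyl untouched, so it bears only loosely on this change. The other replaces phenoxymethyl itself with 4-chlorophenyl on the carbonyl carbon, giving a 1.5-fold higher number from compound 2 to compound 3 (0.17 log units; within the scatter), and that is the closer guide. Within the data shown here, no measured compound carries methyl here, so the evidence is thin. Going by that second step, no change beyond the scatter is expected in this assay. The estimated step is a 1.7-fold higher number from compound 1 to compound 4 (0.23 log units; within the scatter) and the uncertainty around it is wide. Compound 4 is estimated at 28000 nM with an expected range of 10000 nM to 80000 nM on this scale.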

Compound 4, half-maximal inhibitory concentration: 111000 nM
For compound 4 the middle estimate is 4.0-fold (0.60 log units) below the measured one; the measured number lies above the stated range.
By their numbers in this assay, from the lowest: compound 1; then compounds 2 and 3 (each within the scatter of the next); then compound 4.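

In this assay the phenoxy group proves to matter at this place: with hydrogen in its stead on the saturated chain carbon bound to a carbonyl carbon, phenoxymethyl becomes methyl and the result is a 6.7-fold higher number from compound 1 to compound 4 (0.83 log units; beyond the scatter), a clear loss of inhibition. The earlier change at this carbonyl carbon, phenoxymethyl to 4-chlorophenyl, gave only a 1.5-fold higher number from compound 2 to compound 3 (0.17 log units; within the scatter), but there both groups carry a six-membered aromatic ring of carbon only, whereas methyl carries none, and that step was read with 3,4-dihydroxyphenyl rather than 2,3-dihydroxyphenyl on the core. Nothing available gives a reason for this rise in the number.

The compounds shown do not separate the ring from the oxygen of the phenoxy group, so a plain benzyl group or a longer chain such as propyl, or an amine or a carboxylic acid at this place, could each tell more about what the phenoxy group contributes. As far as these compounds go, it also remains open whether the same change from phenoxymethyl to methyl would cost as much with 3,4-dihydroxyphenyl on the core.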